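Urea to amide: replacing cyclohexylamino with pentyl

The compounds below may be only part of what the source reports. "The series", "measured", "known", "first", "only" and "open" are said of these compounds alone.

Three measured compounds share one core, differing only in the group attached through the carbonyl. Compound 1 `CCCCNC(=O)Nc1c(OCCCn2cnc(-c3ccccc3)c2)cccc1N(C)C` gives 810 nM in an assay on aorta for inhibition of acyl-CoA:cholesterol acyltransferase (Oryctolagus cuniculus); on this read-out higher numbers stand for weaker inhibition and lower numbers for stronger inhibition. Compound 2 `CCCNC(=O)Nc1c(OCCCn2cnc(-c3ccccc3)c2)cccc1N(C)C` gives 7230 nM, and compound 3 `CN(C)c1cccc(OCCCn2cnc(-c3ccccc3)c2)c1NC(=O)NC1CCCCC1` gives 1070 nM. Compound 3 therefore sits second highest of the three, close to compound 1, the two lying within the scatter of each other, while compound 2 lies clearly higher, a 6.8-fold lower number from compound 2 to compound 3 (0.83 log units; beyond the scatter).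

The measured steps concern the alkyl group on the amide-type nitrogen: an 8.9-fold higher number from compound 1 to compound 2 (0.95 log units; beyond the scatter), a 1.3-fold higher number from compound 1 to compound 3 (0.12 log units; within the scatter) and a 6.8-fold lower number from compound 2 to compound 3 (0.83 log units; beyond the scatter). The step to compound 4 `CCCCCC(=O)Nc1c(OCCCn2cnc(-c3ccccc3)c2)cccc1N(C)C` is different in kind: pentyl in place of cyclohexylamino on a carbonyl carbon. Within the data shown here, no measured pair shows a cyclohexylamino group exchanged for a chain on the carbonyl carbon, so the measured steps bear on it only loosely, showing that chains and rings of a few carbons near the carbonyl can swing the result modestly. With the hydrogen-bond donor gone and nothing directly comparable in hand, compound 4 is expected to land near or somewhat above compound 3, a 1.9-fold higher number from compound 3 to compound 4 (0.27 log units; within the scatter), with an estimated value of 2000 nM, ranging from 600 nM to 7000 nM.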

Compound 4, half-maximal inhibitory concentration: 100 nM
The estimate for compound 4 lay 20-fold (1.30 log units) above the measured number, outside the stated range (below it).
By their numbers in this assay, from the lowest: compound 4; then compounds 1 and 3 (each within the scatter of the next); then compound 2.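

Until now only the group on the outer nitrogen of the urea had changed; compound 4 removes that nitrogen and its hydrogen-bond donor, leaving pentyl on the carbonyl carbon. In this assay, the amide gives a lower number than each urea, by a margin beyond the scatter every time (an 11-fold lower number from compound 3 to compound 4 (1.03 log units; beyond the scatter); an 8.1-fold lower number from compound 1 to compound 4 (0.91 log units; beyond the scatter); a 72-fold lower number from compound 2 to compound 4 (1.86 log units; beyond the scatter)). Among these four compounds, then, the urea nitrogen is not needed for strong inhibition, and compound 4 is the strongest inhibitor, while the butylamino to pentyl exchange shows that the gain appears even when the group on the carbonyl stays a straight chain.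

Nothing shown here explains why the amide gives the lower number. From the compounds shown here alone, it also remains open whether the low number belongs to the amide link in general or to pentyl in particular, since a butyl, a hexyl or a cyclohexyl group on the same carbonyl carbon would be needed to separate the two.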